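The source may hold more compounds than are shown below. What is called first, only, known or untested is meant among the compounds shown, and "the series" means these compounds.

Of the compounds shown here, three built on a shared core have been tested in an assay on membranes from brain for displacement of a labelled ligand from adenosine receptor A1 (Rattus norvegicus), read by scintillation counting, with a stated time of 90 min; a higher number here means a weaker inhibitor, a lower number a stronger inhibitor. Compound 1 `COc1cccc(/C=C/C(=O)Nc2nc3ccccc3c(=O)s2)c1` gives 205 nM in this assay, and it is the only one of the three to return a number at all. Compound 2 `O=C(COc1cccc(Cl)c1)Nc1nc2ccccc2c(=O)s1` reaches only the limit of the assay, > 10000 nM. Compound 3 `CN(C(=O)CCCc1ccccc1)c1nc2ccccc2c(=O)s1` likewise stops at the limit, > 10000 nM. So compound 1 stands alone with a measured value, while the other two sit at the limit of > 10000 nM in this assay, at which 2 of the 3 values shown sit.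

Compound 4 `O=C(/C=C/c1cccc(Cl)c1)Nc1nc2ccccc2c(=O)s1` differs from compound 1 in one place: chloro in place of methoxy on an aromatic carbon. The rest of the molecule, including the chain that joins the ring to the core, is unchanged. Among the compounds with values here, no measured pair in this set shows the effect of such a swap, so nothing here fixes its size or direction. The change is expected to move the value by no more than the usual scatter, with the step from compound 1 to compound 4 estimated at a 1.3-fold lower number from compound 1 to compound 4 (0.11 log units; within the scatter). Compound 4 is therefore expected to give about 160 nM in this assay, in a range from 50 nM to 600 nM.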

Compound 4, inhibition constant: >= 10000 nM
Compound 4: no number, only a limit; the forecaster's own chance of this, stated with the estimate: 10%; middle value at least 62-fold (1.79 log units) from the limit.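

In this assay, within the data shown here, chloro in place of methoxy on an aromatic carbon gives an at least 48-fold higher number from compound 1 to compound 4 (1.68 log units; beyond the scatter), the first single-place comparison in this set. The rest of the molecule is unchanged, so this one ring substituent alone separates a measured value from no measured value, and the position cannot be treated as tolerant of any small group. The true size of the step remains unknown, as the result for compound 4 is a limit and not a number: the limit of >= 10000 nM in this assay, at which 1 of the 4 values shown sits.

A single swap cannot show which feature of the methoxy group matters, and the data give no cause for the loss. From the compounds shown here alone, whether a hydroxyl, a methyl, an ethoxy or an amine at this position would keep a value near that of compound 1 remains open, as does the effect of moving the methoxy elsewhere on the ring.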